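The source may report more compounds than this note shows. Statements on the series, on what has been measured and on what is new or still open speak of the compounds shown alone.

Among the compounds with values here, in a functional assay on HeLa cells (Homo sapiens) for inhibition (a higher number here means a weaker inhibitor, a lower number a stronger inhibitor), compound 1 `Cc1cn(/C=C/C=O)c(=O)[nH]c1=O` gives 23000 nM, the only true number among the three measured compounds. Compound 2 `Nc1ccn(/C=C/C=O)c(=O)n1` reads > 100000 nM, which is a limit and not a number. Compound 3 `Nc1nc(O)c2ncn(/C=C/C=O)c2n1` reads > 100000 nM, which is also a limit. Compound 4 `O=C/C=C/n1ccc(=O)[nH]c1=O` has not yet been measured. It differs from compound 1 by a single change (hydrogen in place of methyl on an aromatic carbon), hydrogen in place of methyl on an aromatic carbon. Within the data shown here, no measured pair shows what this change does, so any forecast is uncertain. A small weakening is expected, about the size of the usual scatter, and the estimated step is a 2.0-fold higher number from compound 1 to compound 4 (0.29 log units; within the scatter). For compound 4 the estimated value is 45000 nM, with an expected range of 15000 nM to 100000 nM.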

Compound 4, half-maximal inhibitory concentration: 30000 nM
Beside the measured number, compound 4's estimate is 1.5-fold (0.18 log units) above it; the measured number falls inside the stated range.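

In this assay, within the data shown here, hydrogen in place of methyl on this aromatic carbon gives a 1.3-fold higher number from compound 1 to compound 4 (0.12 log units; within the scatter) as the first measured step at this position. The methyl is therefore not needed for the inhibition seen with compound 1, and compound 4 still gives a true number rather than a limit. Nothing shown here gives a reason for this result.

On these data alone, whether an ethyl chain, an amine or a carboxylic acid on this carbon would move the number stays open. A single step within the scatter cannot show how sensitive this position is.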